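This account rests on a few compounds, and the source may have more. Where it says the series, first, only, none or still open, it means among the compounds named here.

Series notes. In a functional assay on P388 cells (Mus musculus) for inhibition (on this read-out lower numbers stand for stronger inhibition and higher numbers for weaker inhibition), compound 1 `O=C1/C(=C/c2ccccc2)CCc2ccccc21` gives 30200 nM and compound 2 `O=C1/C(=C/c2cccc(F)c2)CCc2ccccc21` gives 31100 nM. The change fluoro in place of hydrogen on an aromatic carbon produced a 1.0-fold higher number from compound 1 to compound 2 (0.01 log units; within the scatter). Compound 3 `O=C1CCCCC/C1=C\c1ccccc1` carries a different core; the difference between the two cores is not broken down here. For compound 3 in this assay only a limit is reported, > 50000 nM, at the limit of > 50000 nM in this assay, at which 1 of the 3 values shown sits. Compound 4 `O=C1CCCCC/C1=C\c1cccc(F)c1` is not yet measured; it differs from compound 3 by fluoro in place of hydrogen on an aromatic carbon, the same kind of change as before, though the place is described as meta to a group of 9 heavy atoms rather than meta to a large group. Since that change gave a 1.0-fold higher number from compound 1 to compound 2 (0.01 log units; within the scatter), the step from compound 3 to compound 4 in this assay is expected to be a step that the limit leaves unreadable from compound 3 to compound 4. Compound 4 is therefore estimated at 70000 nM, between 30000 nM and 160000 nM, and will probably again be reported only as a limit.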

Compound 4, half-maximal inhibitory concentration: > 50000 nM
Compound 4: a limit, no number; the forecaster's own chance of this, stated with the estimate: 75%; the middle value does not contradict the limit.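

Compound 3 and compound 4 each give only a limit and no number, so no step can be read between them: the limit of > 50000 nM in this assay, at which 2 of the 4 values shown sit.

The compounds shown leave open what fluoro in place of hydrogen does on the core of compound 3 in this assay.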